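Carbonyl substituent survey on a fused thiophene series

This account rests on a few compounds, and the source may have more. Where it says the series, first, only, none or still open, it means among the compounds named here.

Measured so far in a functional assay on CHO cells for agonist activity at adenosine receptor A1 (Homo sapiens), read by ERK phosphorylation, tested at 3 uM; on this read-out higher numbers stand for a stronger effect at the one concentration tested and lower numbers for a weaker effect:
- compound 1, `NNC(=O)c1c(N)sc2c1CCCCCC2`, 48%
- compound 2, `Nc1sc2c(c1C(=O)NCc1ccccc1)CCCCCC2`, 48%
- compound 3, `NC(=O)c1c(N)sc2c1CCCCCC2`, 48%

Compound 3 stands level with compounds 1 and 2 in this assay; its nearest neighbour by value is compound 1 and its furthest is compound 2, and neither gap exceeds the scatter. The three measured steps all lie on the same nitrogen: no change at the digits printed from compound 1 to compound 2 (within the scatter); no change at the digits printed from compound 1 to compound 3 (within the scatter); no change at the digits printed from compound 2 to compound 3 (within the scatter). None of them moved the read-out beyond the scatter.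

Compound 4, `Cc1ccc(C(=O)c2c(N)sc3c2CCCCCC3)cc1`, is not yet measured. It differs from compound 3 as follows: 4-methylphenyl in place of amino on a carbonyl carbon. This change sits on the carbonyl carbon rather than on the nitrogen, so the measured steps bear on it only indirectly; they show that the read-out of this assay has so far been indifferent to what is attached at the amide end of the carbonyl, whether hydrogen, amino or benzyl. On that basis the step from compound 3 to compound 4 is expected to be small, a number 3 percentage points lower from compound 3 to compound 4 (within the scatter), with no direction beyond the scatter. Compound 4 is therefore estimated at 45%, in a range from 20% to 70%.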

Compound 4, a percentage reported as activity, at one concentration (the size of the read-out at that concentration, not a potency): 56%
Compound 4: middle estimate off by 11 percentage points, on the low side; the measured number falls inside the stated range.
By their numbers in this assay, from the lowest: compounds 1, 2, 3 and 4 (each within the scatter of the next).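

In this assay, the carbonyl carbon tolerates more than the amide nitrogen survey could show: exchanging amino for 4-methylphenyl removes the nitrogen from that carbon altogether and gives a number 8 percentage points higher from compound 3 to compound 4 (within the scatter), while exchanging the aminoamino group for 4-methylphenyl gives a number 8 percentage points higher from compound 1 to compound 4 (within the scatter). The read-out therefore does not depend, within the scatter and at the one concentration tested, on a nitrogen on the carbonyl carbon, even when the hydrogen-bond donor of amino is lost and a six-membered aromatic ring enters at that place. Nothing on hand explains this tolerance.

The read-outs of these compounds stay within the scatter of each other at the one concentration tested, and these data leave open whether the compounds would differ in the size of their effect at any other concentration. They also leave open whether a hydroxyl, as in the carboxylic acid, a methoxy, as in the methyl ester, or an unsubstituted phenyl on the carbonyl carbon would move the read-out beyond the scatter.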